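A few compounds are considered here, and "the series" means these few. Any claim that something is new, unique, unknown or untested is made for them only; others in the source may bear on it.

Measured compounds:
compound 1, `C=C(Br)C(=O)Nc1cccc(-c2cn3nc(-c4ccc(CC)cc4)sc3n2)c1`, 3200 nM
compound 2, `C=C(Br)C(=O)Nc1cccc(-c2cn3nc(-c4ccc(C)cc4)sc3n2)c1`, 2000 nM

In a functional assay on HeLa cells (Homo sapiens) for inhibition, read by cell counting, with a stated time of 4 days (on this read-out higher numbers stand for weaker inhibition and lower numbers for stronger inhibition), compound 2 gives 2000 nM, the lowest of the two numbers recorded so far; its nearest neighbour is compound 1, and the change a 1.6-fold lower number from compound 1 to compound 2 (0.20 log units; within the scatter) lies within the scatter, so the two cannot be ordered. Compound 3 is `C=C(Br)C(=O)Nc1cccc(-c2cn3nc(-c4ccc(OC)cc4)sc3n2)c1`, not yet measured in this assay. It differs from compound 2 by methoxy in place of methyl on an aromatic carbon. Going by the values given here, no measured step touches the methoxy group, and the one step recorded, a 1.6-fold lower number from compound 1 to compound 2 (0.20 log units; within the scatter), concerns a different change at the same ring and was itself within the scatter. On that evidence no shift beyond the scatter is expected, and the step of no change at the digits printed from compound 2 to compound 3 (within the scatter) is the estimate. Compound 3 is therefore expected to give about 2000 nM in this assay, with a range from 800 nM to 5000 nM.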

Compound 3, half-maximal inhibitory concentration: 2300 nM
Beside the measured number, compound 3's estimate is 1.2-fold (0.06 log units) below it, within the range that was stated.
By their numbers in this assay, from the lowest: compounds 2, 3 and 1 (each within the scatter of the next).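

In this assay, going by these compounds alone, the first change at this position to add an oxygen and a hydrogen-bond acceptor gives a 1.2-fold higher number from compound 2 to compound 3 (0.06 log units; within the scatter), and replacing ethyl with methoxy gives a 1.4-fold lower number from compound 1 to compound 3 (0.14 log units; within the scatter). The position para to a large group has now carried methyl, ethyl and methoxy, and the three compounds cannot be ordered, so within this small set the exchange of these groups shows no effect beyond the scatter. No further data bear on why the numbers stay so close.

Whether any group at this position can move the number beyond the scatter remains open, since an amine, a carboxylic acid and a longer chain such as butyl are not among the compounds shown. On these data alone, all three compounds share the rest of the structure, so the effect of changes elsewhere is also open.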